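From 2-Chlorophenyl to 3-Chlorophenyl on a Shared Core

The source may hold more compounds than are shown below. What is called first, only, known or untested is meant among the compounds shown, and "the series" means these compounds.

In a functional assay on MCF7 cells (Homo sapiens) for cytotoxicity, read by MTT assay, with a stated time of 96 h (a higher number here means a weaker inhibitor, a lower number a stronger inhibitor), compound 1 `COc1cc(C(=O)c2cn(-c3ccccc3Cl)cc2-c2ccccc2)cc(OC)c1OC` gives 1800 nM, the middle of three numbers. Compound 2 `COc1cc(C(=O)c2cn(-c3ccccc3[N+](=O)[O-])cc2-c2ccccc2)cc(OC)c1OC` gives 5000 nM, and compound 3 `COc1ccccc1-n1cc(C(=O)c2cc(OC)c(OC)c(OC)c2)c(-c2ccccc2)c1` gives 150 nM. These two carry another group in place of the chloro group: nitro brings a 2.8-fold higher number from compound 1 to compound 2 (0.44 log units; beyond the scatter), a modest step, and methoxy brings a 12-fold lower number from compound 1 to compound 3 (1.08 log units; beyond the scatter), a large one. Between those two groups lies a 33-fold lower number from compound 2 to compound 3 (1.52 log units; beyond the scatter). Compound 4 `COc1cc(C(=O)c2cn(-c3cccc(Cl)c3)cc2-c2ccccc2)cc(OC)c1OC` keeps the chlorine but has it elsewhere: 3-chlorophenyl in place of 2-chlorophenyl on an aromatic nitrogen. Within the data shown here, no measured step moves a group in this way, so these steps give only loose guidance, and no clear direction follows from them. The expected change is small, a 1.5-fold lower number from compound 1 to compound 4 (0.18 log units; within the scatter), with no step beyond the scatter foreseen. For compound 4 the estimate is 1200 nM, with an expected range from 300 nM to 4500 nM.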

Compound 4, half-maximal inhibitory concentration: 150 nM
Compound 4: middle estimate off by 8.0-fold (0.90 log units), on the high side; measured number below the stated range.
By their numbers in this assay, from the lowest: compounds 3 and 4 (each within the scatter of the next); then compound 1; then compound 2.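

Moving the chlorine alone, with the same atoms kept, matters in this assay: 3-chlorophenyl in place of 2-chlorophenyl gives a large step (a 12-fold lower number from compound 1 to compound 4 (1.08 log units; beyond the scatter)). The 3-chlorophenyl group also matches 2-methoxyphenyl (no change at the digits printed from compound 3 to compound 4 (within the scatter)) and stands far from 2-nitrophenyl (a 33-fold lower number from compound 2 to compound 4 (1.52 log units; beyond the scatter)). No evidence here explains this shift. The compounds shown leave open whether methoxy or nitro would respond to the same move as chloro does. They also leave open how an amine or a carboxylic acid would fare on this phenyl group.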